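The source may report more compounds than this note shows. Statements on the series, on what has been measured and on what is new or still open speak of the compounds shown alone.

In an ADME assay for cytotoxicity, read by propidium iodide staining (on this read-out higher numbers stand for lower toxicity in this test and lower numbers for higher toxicity in this test), compound 1 (`Cn1nc(Cc2ccc(Cl)cc2Cl)c2ccccc2c1=O`) gives 112000 nM. Compound 2 (`Cn1nc(Cc2ccccc2)c2ccccc2c1=O`) is reported only as a limit, > 156000 nM. Compound 3 (`Cn1nc(Cc2ccccc2Cl)c2ccccc2c1=O`) departs from compound 2 in one place: chloro in place of hydrogen on an aromatic carbon, ortho to a large group. In this assay a small move towards lower numbers is expected, close to the scatter, because compound 1 also carries chloro and gives 112000 nM. The expected change is an at least 1.2-fold lower number from compound 2 to compound 3 (0.07 log units; that floor lies within the scatter). For compound 3 the estimate is 130000 nM, with an expected range from 80000 nM to 210000 nM.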

Compound 3, half-maximal cytotoxic concentration: > 176000 nM
Compound 3: no number, only a limit; the forecaster's own chance of this, stated with the estimate: 40%; middle value at least 1.3-fold (0.13 log units) from the limit.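

Compound 3 shows that chloro on an aromatic carbon, ortho to a large group, still yields only a limit in this assay, as compound 2 does, so the step between these two cannot be read. Hydrogen in place of chloro on an aromatic carbon gives an at least 1.5-fold higher number from compound 1 to compound 3 (0.19 log units; that floor lies within the scatter). Of the three compounds, only compound 1, with its two chloro groups, has a number rather than a limit.

Going by these compounds, how far the values of compound 2 and compound 3 truly lie from each other stays open. So does how a methoxy group or an amine in place of this chloro would read in this assay.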